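Cyclopropyl Amide Expected to Stay at the Clearance Limit

This account rests on a few compounds, and the source may have more. Where it says the series, first, only, none or still open, it means among the compounds named here.

Of the compounds shown here, three sharing one core have been measured in an ADME assay on cells (Hepatocyte, Homo sapiens) for pharmacokinetics, read by LC-MS, tested at 0.5 uM; a lower number here means slower removal, a higher number faster removal of the compound. Compound 1 `CNC(=O)c1cc(C(=O)NC2CC2)cc2c1O[C@H](CO)[C@H]2c1ccccc1` carries a cyclopropyl group on an amide-type nitrogen. In this assay compound 1 gives < 0.45 mL/min, which is a limit of the assay rather than a number. Compound 2 `CNC(=O)c1cc(C(=O)N[C@H]2C[C@H](O)C2)cc2c1O[C@H](CF)[C@H]2c1ccccc1` carries a 3-hydroxycyclobutyl group on that amide-type nitrogen. In this assay compound 2 gives < 0.45 mL/min, again a limit. Compound 3 `CNC(=O)c1cc(C(=O)NC)c2c(c1)[C@H](c1ccccc1)[C@@H](CF)O2` carries a methyl on the same amide-type nitrogen. In this assay compound 3 gives < 0.45 mL/min, also a limit. The step that the two limits leave unreadable from compound 2 to compound 3 therefore cannot be read as a size. Compound 4 `CNC(=O)c1cc(C(=O)NC2CC2)cc2c1O[C@H](CF)[C@H]2c1ccccc1` is the compound still to be measured, and its change from compound 3 is cyclopropyl in place of methyl on an amide-type nitrogen. Among the compounds with values here, no measured step gives a readable number, but compound 1 already carries the cyclopropyl group on the amide-type nitrogen, and the limit of < 0.45 mL/min in this assay, at which 3 of the 3 values shown sit, covers every value shown. Compound 4 is therefore expected to return a limit as well, with an estimated 0.3 mL/min and a range from 0.1 mL/min to 0.6 mL/min. The step that the limit leaves unreadable from compound 3 to compound 4 is expected to be nothing beyond the scatter.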

Compound 4, intrinsic clearance in a liver preparation (reported as CLH), per the amount of preparation that the assay uses: < 0.45 mL/min
Compound 4 was reported as a limit (the forecaster's own chance of this, stated with the estimate: 85%); the middle value is on the limit's open side.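

In this assay, the steps from compound 1, compound 2 and compound 3 to compound 4 cannot be read as sizes, since all four compounds share one assay limit: the limit of < 0.45 mL/min in this assay, at which 4 of the 4 values shown sit.

The compounds shown leave open how fast each is actually removed, and whether the group on the amide-type nitrogen, or fluoro in place of hydroxy, changes that at all.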